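This account rests on a few compounds, and the source may have more. Where it says the series, first, only, none or still open, it means among the compounds named here.

Compound 3, with structure `CC(C)c1onc(-c2c(Cl)cccc2Cl)c1COc1ccc(-c2ccc3nc(C(=O)O)cc(O)c3c2)cc1`, gives 51 nM in a functional assay for agonist activity at Bile acid receptor (Homo sapiens), read by FRET (a lower number here means that less compound is needed, a higher number that more compound is needed for the effect), the lowest of the three numbers recorded. Its nearest neighbour is compound 1, `CC(C)c1onc(-c2c(Cl)cccc2Cl)c1COc1ccc(-c2ccc3cc(C(=O)O)cnc3c2)cc1`, which in this assay gives 200 nM, a gap beyond the scatter; furthest away is compound 2, `Cc1cc(OCc2c(-c3c(Cl)cccc3Cl)noc2C(C)C)ccc1-c1ccc2nc(C(=O)O)ccc2c1`, which gives 250 nM in this assay, also beyond the scatter.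

Compound 4, with structure `CC(C)COc1cc(C(=O)O)nc2ccc(-c3ccc(OCc4c(-c5c(Cl)cccc5Cl)noc4C(C)C)cc3)cc12`, has not yet been measured. It differs from compound 3 in one place: isobutyl in place of hydrogen on an oxygen on an aromatic ring. Within the data shown here, no measured pair shows this change, so its size cannot be read off from the data. With the hydroxy group of compound 3 already the best-performing variation seen, and a four-carbon chain now attached to that oxygen, the step from compound 3 to compound 4 is expected to be small, within or only just beyond the scatter, with no clear direction; the expected step is a 1.4-fold higher number from compound 3 to compound 4 (0.14 log units; within the scatter). For compound 4 the estimate in this assay is 70 nM, with a range from 20 nM to 250 nM.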

Compound 4, half-maximal effective concentration: 78 nM
For compound 4 the middle estimate is 1.1-fold (0.05 log units) below the measured one; low and high end bracket the measured number.
By their numbers in this assay, from the lowest: compounds 3 and 4 (each within the scatter of the next); then compounds 1 and 2 (each within the scatter of the next).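

Replacing hydrogen with isobutyl on this oxygen on an aromatic ring gives a 1.5-fold higher number from compound 3 to compound 4 (0.18 log units; within the scatter) in this assay, so the readout does not separate the hydroxy group from the isobutoxy group at this place. This is the first pair among the compounds shown that differs in one place, since compounds 1, 2 and 3 differ from one another in more than one place and no step can be read among them. Nothing available gives a reason for this result.

On these data alone, whether methyl, a longer chain or a chain ending in a carboxylic acid on the same oxygen would also stay within the scatter of compound 3 remains open. A single step at this place cannot show how far the oxygen tolerates other groups, or whether any group would lower the number.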